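Proline amide capping group: neopentyl to dimethylaminomethyl

A few compounds are considered here, and "the series" means these few. Any claim that something is new, unique, unknown or untested is made for them only; others in the source may bear on it.

Three capped analogues share one core. Compound 1 `CC(C)(C)OC(=O)N1CCC[C@H]1C(=O)N1CCC(NS(=O)(=O)c2cc(S(=O)(=O)c3ccccc3)ccc2C(F)(F)F)CC1` carries a tert-butoxy on the carbonyl carbon and gives 60 nM in an assay on isolated protein for binding affinity to secreted frizzled-related protein 1 (Homo sapiens), read by fluorescence; on this read-out higher numbers stand for weaker inhibition and lower numbers for stronger inhibition. Compound 2 `CC(=O)N1CCC[C@H]1C(=O)N1CCC(NS(=O)(=O)c2cc(S(=O)(=O)c3ccccc3)ccc2C(F)(F)F)CC1` carries a methyl there and gives 160 nM. Compound 3 `CC(C)(C)CC(=O)N1CCC[C@H]1C(=O)N1CCC(NS(=O)(=O)c2cc(S(=O)(=O)c3ccccc3)ccc2C(F)(F)F)CC1` carries a neopentyl and gives 20 nM, the lowest of the three numbers; its nearest neighbour is compound 1, and the step of a 3.0-fold lower number from compound 1 to compound 3 (0.48 log units; beyond the scatter) lies beyond the scatter, as does an 8.0-fold lower number from compound 2 to compound 3 (0.90 log units; beyond the scatter).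

Compound 4 `CN(C)CC(=O)N1CCC[C@H]1C(=O)N1CCC(NS(=O)(=O)c2cc(S(=O)(=O)c3ccccc3)ccc2C(F)(F)F)CC1` has not been measured. It differs from compound 3 in one place: dimethylamino in place of tert-butyl on a saturated chain carbon bound to a carbonyl carbon. The measured step that bears most directly on this is an 8.0-fold lower number from compound 2 to compound 3 (0.90 log units; beyond the scatter), which shows what a tert-butyl on that saturated chain carbon adds; compound 4 removes that tert-butyl and puts a dimethylamino in its place, so part of that gain is expected to be given back. The step of a 3.0-fold lower number from compound 1 to compound 3 (0.48 log units; beyond the scatter) shows that other groups on the carbonyl carbon also land above compound 3. Compound 4 is therefore expected to give a higher number than compound 3, an estimated step of a 4.0-fold higher number from compound 3 to compound 4 (0.60 log units; beyond the scatter), but to stay below compound 2. The expected value for compound 4 is 80 nM, with a range from 25 nM to 250 nM.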

Compound 4, half-maximal inhibitory concentration: 90 nM
Compound 4: the middle estimate sits 1.1-fold (0.05 log units) below what was measured; measured number inside the range.
By their numbers in this assay, from the lowest: compound 3; then compounds 1, 4 and 2 (each within the scatter of the next, the first and the last beyond it).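

In this assay, dimethylamino in place of tert-butyl on a saturated chain carbon bound to a carbonyl carbon gives a 4.5-fold higher number from compound 3 to compound 4 (0.65 log units; beyond the scatter) and so does not hold the low number of the neopentyl cap. Dimethylamino in place of hydrogen at that carbon gives a 1.8-fold lower number from compound 2 to compound 4 (0.25 log units; within the scatter) and (dimethylamino)methyl in place of tert-butoxy on a carbonyl carbon gives a 1.5-fold higher number from compound 1 to compound 4 (0.18 log units; within the scatter), so among these compounds tert-butyl alone gives a step beyond the scatter from hydrogen at this carbon (in the step of an 8.0-fold lower number from compound 2 to compound 3 (0.90 log units; beyond the scatter)). No measurement accompanying these compounds accounts for the difference between tert-butyl and dimethylamino.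

The compounds shown do not separate the effect of the amine nitrogen from the loss of the tert-butyl carbons, and an isopropyl, a cyclohexyl or a trimethylsilyl group on the same saturated chain carbon would bear on that question. Also open, on these data alone, is how a pyrrolidine or morpholine amine, a carboxylic acid, or a longer chain carrying the dimethylamino would read on this position.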